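The compounds below may be only part of what the source reports. "The series", "measured", "known", "first", "only" and "open" are said of these compounds alone.

Compound 1 `O=C(NCc1cc(Cl)ccc1-n1cnnn1)[C@@H]1C[C@@H]2C[C@@H]2N1C(=O)[C@H](O)Cn1cccn1` gives 0.45 10^-6 cm/s in an ADME assay on Caco-2 cells (Homo sapiens) for permeability, read by LC-MS, in the apical to basolateral direction, with a stated time of 60 min, at pH 6.5; on this read-out higher numbers stand for higher permeability and lower numbers for lower permeability. Compound 2 `O=C(NCc1cc(Cl)ccc1-n1cnnn1)[C@@H]1C[C@@H]2C[C@@H]2N1C(=O)[C@H](O)C1CCCCC1` gives 16 10^-6 cm/s in this assay. Compound 3 `O=C(NCc1cc(Cl)ccc1-n1cnnn1)[C@@H]1[C@H]2C[C@H]2CN1C(=O)[C@H](O)C1CCCCC1` gives 25 10^-6 cm/s in this assay.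

Compound 2 and compound 3 are built from the same atoms joined differently; the difference between the two cores is not broken down here, and their two values lie within the scatter of each other. Compound 1 differs from compound 2 by (1H-pyrazol-1-yl)methyl in place of cyclohexyl on a saturated chain carbon bound to a carbonyl carbon and an oxygen on a saturated carbon, and that change made a 36-fold lower number from compound 2 to compound 1 (1.55 log units; beyond the scatter).

Compound 4 `O=C(NCc1cc(Cl)ccc1-n1cnnn1)[C@@H]1[C@H]2C[C@H]2CN1C(=O)[C@H](O)Cn1cccn1` has not yet been measured in this assay. Among the compounds with values here, it differs from compound 3 by (1H-pyrazol-1-yl)methyl in place of cyclohexyl on a saturated chain carbon bound to a carbonyl carbon and an oxygen on a saturated carbon, which is the same change at the same place as the one that took compound 2 to compound 1. On that footing compound 4 is expected to fall by a 36-fold lower number from compound 3 to compound 4 (1.55 log units; beyond the scatter), because the same change gave a 36-fold lower number from compound 2 to compound 1 (1.55 log units; beyond the scatter); the only qualification is that its core is that of compound 3, not compound 2, and the core difference is not broken down. Compound 4 is thus estimated at 0.7 10^-6 cm/s, with a likely range from 0.3 10^-6 cm/s to 1.8 10^-6 cm/s.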

Compound 4, apparent permeability: 0.31 10^-6 cm/s
For compound 4 the middle estimate is 2.3-fold (0.35 log units) above the measured one; the measured number falls inside the stated range.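

In this assay, (1H-pyrazol-1-yl)methyl in place of cyclohexyl on the second core again made a large difference, an 81-fold lower number from compound 3 to compound 4 (1.91 log units; beyond the scatter). Set beside the earlier step, the two results show that the change carried over from one core to the other with no difference in size beyond the scatter: the same change on two cores in this assay, a 36-fold lower number (1.55 log units; beyond the scatter) from compound 2 to compound 1 and an 81-fold lower number (1.91 log units; beyond the scatter) from compound 3 to compound 4, 2.3-fold (0.36 log units) apart, within the scatter of two such steps. This supports reading the change as transferable for these two cores only; it does not show that the same would hold on any further core, and it gives no explanation of why the number falls so far.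

The compounds shown leave open how the read-out responds to other groups at this place, such as an amine, a carboxylic acid, a phenyl ring or a longer chain, since only cyclohexyl and (1H-pyrazol-1-yl)methyl appear there. They also leave open what the neighbouring parts of the molecule contribute, as the chlorine and the tetrazole-bearing ring stay the same throughout.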